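The source may hold more compounds than are shown below. What is called first, only, known or untested is meant among the compounds shown, and "the series" means these compounds.

In an ADME assay on Vero cells (Chlorocebus sabaeus) for cytotoxicity, read by reporter gene assay, with a stated time of 4 days (on this read-out lower numbers stand for stronger inhibition and higher numbers for weaker inhibition), compound 1 (`CCCC(C)C(=O)OCC(C)(C)CC1=C(O)C(=O)c2ccccc2C1=O`) gives 120 nM, compound 2 (`CCCCCCC(C)C(=O)OCC(C)(C)CC1=C(O)C(=O)c2ccccc2C1=O`) gives 450 nM, and compound 3 (`CCCCCCCCC(=O)OCC(C)(C)CC1=C(O)C(=O)c2ccccc2C1=O`) gives 150000 nM, the highest of the three numbers. Compound 4 (`CCCCCCCCCCCCCC(=O)OCC(C)(C)CC1=C(O)C(=O)c2ccccc2C1=O`) lengthens the straight chain of compound 3, and the change is pentyl in place of hydrogen on a saturated chain carbon, eight bonds along the chain from a carbonyl carbon. Going by the values given here, the closest precedent is also a lengthening, a 3.8-fold higher number from compound 1 to compound 2 (0.57 log units; beyond the scatter), which is a modest step. The other two steps, a 1300-fold higher number from compound 1 to compound 3 (3.10 log units; beyond the scatter) and a 330-fold higher number from compound 2 to compound 3 (2.52 log units; beyond the scatter), are large, but each replaces a 1-methyl-substituted chain with octyl, a different kind of change. A modest move to a higher number is therefore expected in this assay. The expected size is a 3.0-fold higher number from compound 3 to compound 4 (0.48 log units; beyond the scatter). For compound 4 the estimated value is 450000 nM, with a range of 120000 nM to 1500000 nM.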

Compound 4, half-maximal inhibitory concentration: 58400 nM
Compound 4: middle estimate off by 7.7-fold (0.89 log units), on the high side, and the stated range ends above it.
By their numbers in this assay, from the lowest: compound 1; then compound 2; then compound 4; then compound 3.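

Within this assay pentyl in place of hydrogen, eight bonds along the chain from a carbonyl carbon, gives a 2.6-fold lower number from compound 3 to compound 4 (0.41 log units; beyond the scatter) and so moves the number down, whereas the earlier lengthening of a branched chain, at a different place, gave a 3.8-fold higher number from compound 1 to compound 2 (0.57 log units; beyond the scatter) in the opposite direction. Adding carbons to the chain therefore has no single direction across these compounds. Nothing measured here accounts for this difference. On these data alone, whether a still longer chain at this place would lower the number further remains open. So does how an amine or a carboxylic acid there would compare.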